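This account rests on a few compounds, and the source may have more. Where it says the series, first, only, none or still open, it means among the compounds named here.

Measured compounds:
- compound 1 `N[C@H]1CC[C@H](Nc2c(C(=O)NCc3ccc(Oc4ccccc4)cc3)nc(Br)c3cccnc23)CC1`: "not determined" (no result reported) in a functional assay on HCT-116 cells (Homo sapiens) for cytotoxicity, read by MTT assay, with a stated time of 72 h; on this read-out lower numbers stand for stronger inhibition and higher numbers for weaker inhibition
- compound 2 `CNCCCNc1c(C(=O)NCc2ccc(F)cc2)nc(Br)c2cccnc12`: 9000 nM in this assay

Compound 1 carries a phenoxy group on the benzyl amide and a trans-aminocyclohexyl group on the shared core, but for compound 1 this assay reports no number at all, so it stands nowhere on the numbers shown. For the measured compounds named here, the only measured point is compound 2, which in this assay gives 9000 nM; it shares the core with compound 1 but differs in the amide side and in the amine side, so no single step can be drawn between them.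

Compound 3 `N[C@H]1CC[C@H](Nc2c(C(=O)NCc3ccccc3)nc(Br)c3cccnc23)CC1` is compound 1 with one change: hydrogen in place of phenoxy on an aromatic carbon. Going by the values given here, with no measured pair for this change, the step is expected to stay within the usual scatter of this assay, in no settled direction. Compound 3 is therefore estimated at 10000 nM, expected to lie between 3000 nM and 40000 nM.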

Compound 3, half-maximal inhibitory concentration: 7000 nM
Compound 3: the middle estimate sits 1.4-fold (0.15 log units) above what was measured; low and high end bracket the measured number.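

No new step can be read from compound 3: compound 1 has no number to compare with it in this assay, and compound 2 differs from it in more than one place. No evidence on causes is available here. From the compounds shown here alone, whether swapping phenoxy for hydrogen changes the value remains open.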